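Adding a methoxy to the carbonyl-side ring

The source may hold more compounds than are shown below. What is called first, only, known or untested is meant among the compounds shown, and "the series" means these compounds.

Two compounds share a core, differing only in the ring on the carbonyl carbon. Compound 1 `COc1cc(-c2cc(/C=C/C(=O)c3ccc(N)cc3)[nH]n2)cc(OC)c1OC` carries a 4-aminophenyl there; in a functional assay on PC-3 cells (Homo sapiens) for inhibition, read by sulforhodamine B assay, with a stated time of 48 h (on this read-out lower numbers stand for stronger inhibition of growth and higher numbers for weaker inhibition of growth), compound 1 gives 2210 nM. Compound 2 `COc1ccc(C(=O)/C=C/c2cc(-c3cc(OC)c(OC)c(OC)c3)n[nH]2)cc1OC` carries a 3,4-dimethoxyphenyl instead, and in this assay compound 2 gives 1360 nM. The step of a 1.6-fold lower number from compound 1 to compound 2 (0.21 log units; within the scatter) shows that swapping the whole ring left the number within the scatter, so compound 2 stands beside compound 1 with no real separation between them. Compound 3 `COc1cc(C(=O)/C=C/c2cc(-c3cc(OC)c(OC)c(OC)c3)n[nH]2)cc(OC)c1OC` takes the next step on the same ring: methoxy in place of hydrogen on an aromatic carbon. Among the compounds with values here, the only measured step that bears on it, from compound 1 to compound 2, changed this ring far more and still stayed within the scatter, so the step of a 1.0-fold lower number from compound 2 to compound 3 (0.02 log units; within the scatter) is expected to be small. Compound 3 is therefore estimated at 1300 nM, within 500 nM to 3500 nM.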

Compound 3, concentration for 50% growth inhibition: 1470 nM
Estimate against measurement, compound 3: 1.1-fold (0.05 log units) below; low and high end bracket the measured number.
By their numbers in this assay, from the lowest: compounds 2, 3 and 1 (each within the scatter of the next).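

In this assay, the step of a 1.1-fold higher number from compound 2 to compound 3 (0.03 log units; within the scatter) lies within the scatter, so a methoxy on this aromatic carbon, in place of hydrogen, leaves no readable mark on the number. Compound 1 and compound 2 differ in the whole ring on the carbonyl carbon, whereas compound 2 and compound 3 differ at this one place, ortho to a methoxy group and meta to a large group. This single position can therefore carry the extra methoxy, with its two heavy atoms, and the number stays within the scatter of compound 2.

As far as these compounds go, whether an amine or a carboxylic acid at this same place would also stay within the scatter remains open. The same is true of a longer chain, such as ethoxy, in place of the methoxy. Nothing available explains why this step is so small.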